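Permeability notes on the anilino variation of the shared core

The source may report more compounds than this note shows. Statements on the series, on what has been measured and on what is new or still open speak of the compounds shown alone.

Measured compounds in an ADME assay on Caco-2 cells (Homo sapiens) for permeability, in the apical to basolateral direction; on this read-out higher numbers stand for higher permeability and lower numbers for lower permeability:
Compound 1 `CNC(=O)c1cc(Oc2ccc3nc(Nc4cccc(C(C)(C)C)c4)ncc3c2)ccn1`: compound 1 gives < 1 10^-6 cm/s, a limit of the assay.
Compound 2 `CNC(=O)c1cc(Oc2ccc3nc(Nc4cccc(Cl)c4)ncc3c2)ccn1`: compound 2 gives < 1 10^-6 cm/s, a limit of the assay.
Compound 3 `CNC(=O)c1cc(Oc2ccc3nc(Nc4cccc(C(C)C)c4)ncc3c2)ccn1`: compound 3 gives < 1 10^-6 cm/s, a limit of the assay.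

Compound 2 therefore stands at the lower limit of the read-out, and it is not set apart from the other two measured compounds, since (the limit of < 1 10^-6 cm/s in this assay, at which 3 of the 3 values shown sit). The three recorded steps, a step that the two limits leave unreadable from compound 1 to compound 2, a step that the two limits leave unreadable from compound 1 to compound 3 and a step that the two limits leave unreadable from compound 2 to compound 3, are all left unreadable by the limits, so no size of change on the aromatic substituent can be drawn from them.

Compound 4 `CNC(=O)c1cc(Oc2ccc3nc(Nc4ccc(OC(F)(F)F)cc4)ncc3c2)ccn1` is the next member. Compared with compound 2 the change is 4-(trifluoromethoxy)phenyl in place of 3-chlorophenyl on a nitrogen on an aromatic ring. Going by the values given here, none of the measured steps bears on this particular exchange, and even the steps that exist carry no readable size. What the data do show is that every variation on this part of the molecule so far has left the read-out at its floor, which is the only footing for an expectation here. Compound 4 is therefore expected to remain near the limit as well, with a step that the limit leaves unreadable from compound 2 to compound 4 taken as no step beyond the scatter. The estimate for compound 4 is 0.7 10^-6 cm/s, within a range from 0.3 10^-6 cm/s to 2.5 10^-6 cm/s, and a further limit-only result is considered the most likely outcome.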

Compound 4, apparent permeability: < 1 10^-6 cm/s
Compound 4: a limit, no number; the forecaster's own chance of this, stated with the estimate: 70%; the middle value is on the limit's open side.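

Compound 4 ends at a limit of the assay, as do compound 1, compound 2 and compound 3, so none of its steps to those three compounds can be read: the limit of < 1 10^-6 cm/s in this assay, at which 4 of the 4 values shown sit.

The compounds shown leave open where each of the four truly lies in this assay, and whether the exchanged aromatic groups differ at all on this read-out.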